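Replacing 2-fluorophenyl with 4-bromophenyl in compound 2

A few compounds are considered here, and "the series" means these few. Any claim that something is new, unique, unknown or untested is made for them only; others in the source may bear on it.

- Compound 1 `COc1ccc(/C=C2\CN(C)C/C(=C\c3ccccc3F)C2=O)cc1OC`: 10500 nM
- Compound 2 `COc1cc(/C=C2\CN(C)C/C(=C\c3ccccc3F)C2=O)cc(OC)c1`: 11900 nM

Both numbers come from an ADME assay on L02 cells (Homo sapiens) for cytotoxicity, read by MTT assay, with a stated time of 24 h; a lower number here means a stronger inhibitor, a higher number a weaker inhibitor. For the measured compounds named here, only two compounds have been measured so far, and compound 2, at 11900 nM, lies within the usual scatter of compound 1, so the pair cannot be told apart. Both carry the 2-fluorophenyl group. The next compound, compound 3 `COc1cc(/C=C2\CN(C)C/C(=C\c3ccc(Br)cc3)C2=O)cc(OC)c1`, has 4-bromophenyl in place of 2-fluorophenyl on a double-bonded chain carbon bound to a double-bonded ring carbon. Going by the values given here, no measured pair shows a change of this kind, so the data offer no direct guide to its size. In this assay, no step beyond the scatter is expected, with only a slight lean towards a lower number. The expected step is a 1.3-fold lower number from compound 2 to compound 3 (0.10 log units; within the scatter). Compound 3 is estimated at 9500 nM, with an expected range of 3500 nM to 25000 nM.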

Compound 3, half-maximal inhibitory concentration: 21300 nM
For compound 3 the middle estimate is 2.2-fold (0.35 log units) below the measured one, within the range that was stated.
By their numbers in this assay, from the lowest: compounds 1, 2 and 3 (each within the scatter of the next, the first and the last beyond it).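

In this assay, 4-bromophenyl in place of 2-fluorophenyl on a double-bonded chain carbon bound to a double-bonded ring carbon gives a 1.8-fold higher number from compound 2 to compound 3 (0.25 log units; within the scatter). For the compounds shown here, this is the first reading of any change at this position, and it leaves compound 2 and compound 3 impossible to tell apart, so this exchange of one halogen-bearing phenyl group for another has no effect that can be resolved here. No measurement shown accounts for this result.

The halogen and its place on the phenyl group change together in this single step, so their contributions remain unseparated. Still open, from the compounds shown here alone, is how 4-fluorophenyl, 2-bromophenyl, unsubstituted phenyl, or a phenyl group carrying an amine or a carboxylic acid would read at this position.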